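Adding a Chloro Group to a Shared Core: Compound 4

The source may hold more compounds than are shown below. What is called first, only, known or untested is meant among the compounds shown, and "the series" means these compounds.

Measured so far:
Compound 1 `CCOC(=O)c1nn(-c2ccccc2)/c(=N/c2nc(-c3c(C)n(C)n(-c4ccccc4)c3=O)cs2)s1` gives > 100000 nM in a functional assay on A549 cells (Homo sapiens) for cytotoxicity, read by sulforhodamine B assay, with a stated time of 72 h (on this read-out lower numbers stand for stronger inhibition and higher numbers for weaker inhibition), which is a limit of the assay.
Compound 2 `CCOC(=O)c1nn(-c2ccc(Cl)cc2)/c(=N/c2nc(-c3c(C)n(C)n(-c4ccccc4)c3=O)cs2)s1` gives > 100000 nM in this assay, again a limit.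
Compound 3 `Cc1c(-c2csc(/N=C3\S/C(=C\c4ccccc4)C(=O)N3c3ccccc3)n2)c(=O)n(-c2ccccc2)n1C` gives > 100000 nM in this assay, also a limit.

Compound 1 and compound 2 differ by one change: chloro in place of hydrogen on an aromatic carbon. The step that the two limits leave unreadable from compound 1 to compound 2 stays unreadable because all three values sit at the limit of > 100000 nM in this assay, at which 3 of the 3 values shown sit. How the core of compound 3 differs from that of compound 1 is not broken down here. Compound 4 `Cc1c(-c2csc(/N=C3\S/C(=C\c4ccc(Cl)cc4)C(=O)N3c3ccccc3)n2)c(=O)n(-c2ccccc2)n1C` carries the same change relative to compound 3: chloro in place of hydrogen on an aromatic carbon. Since that change left compound 1 and compound 2 both at the limit, compound 4 is expected to remain at the limit too. Compound 4 is expected to give 150000 nM in this assay. The expected step is a step that the limit leaves unreadable from compound 3 to compound 4, resting on the unreadable a step that the two limits leave unreadable from compound 1 to compound 2.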

Compound 4, half-maximal inhibitory concentration: > 100000 nM
Compound 4: only a limit was reported; the forecaster's own chance of this, stated with the estimate: 85%; the middle value is on the limit's open side.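

No step from compound 3 to compound 4 can be read, because both results are limits of this assay and not numbers: the limit of > 100000 nM in this assay, at which 4 of the 4 values shown sit.

Going by these compounds, how strongly any of the four compounds acts on these cells, and whether chloro in place of hydrogen changes that, stays open.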